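This account rests on a few compounds, and the source may have more. Where it says the series, first, only, none or still open, it means among the compounds named here.

Measured compounds:
compound 1 `O=C(NCC1CCCCC1)c1cccc(/C=C2\CC(=O)N(c3ccccc3)C2=O)c1` — in an ADME assay on HCT-116 cells (Homo sapiens) for cytotoxicity, read by MTT assay, with a stated time of 72 h (a higher number here means a weaker inhibitor, a lower number a stronger inhibitor), compound 1 gives > 100000 nM, a limit of the assay.
compound 2 `COc1cc(NC(=O)c2cccc(/C=C3\CC(=O)N(c4ccccc4)C3=O)c2)cc(OC)c1OC` — in this assay compound 2 gives > 100000 nM, again a limit.
compound 3 `CCCCCN1C(=O)C/C(=C\c2cccc(C(=O)Nc3ccc(OC)cc3)c2)C1=O` — in this assay compound 3 gives > 100000 nM, again a limit.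

Compound 1 therefore stands at the limit of this assay, not at a measured number, and the other two measured compounds sit at the same limit; none of the three can be placed above or below another. Going by the values given here, the only evidence available is the limit of > 100000 nM in this assay, at which 3 of the 3 values shown sit, so no real step between measured compounds can be counted.

Compound 4 `O=C(Nc1ccc(OC(F)F)cc1)c1cccc(/C=C2\CC(=O)N(c3ccccc3)C2=O)c1` has not yet been measured. It differs from compound 1 in one place: 4-(difluoromethoxy)phenyl in place of cyclohexylmethyl on an amide-type nitrogen.

Since every measured compound sits at the limit, the most likely outcome for compound 4 is that it too is reported only as a limit. The change from compound 1 to compound 4 is expected to make no step beyond the scatter, that is, a number no higher from compound 1 to compound 4 (the limit leaves the size open) is expected to be essentially none. Compound 4 is therefore estimated at 100000 nM, with a range from 40000 nM to 300000 nM, most probably reported as a limit rather than a number.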

Compound 4, half-maximal inhibitory concentration: > 100000 nM
Compound 4 was reported as a limit; the forecaster's own chance of this, stated with the estimate: 80%; the middle value lies on the limit itself.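

Compound 1 and compound 4 both stand at a limit of the assay, not at a number, so no step can be read from putting 4-(difluoromethoxy)phenyl in place of cyclohexylmethyl: the limit of > 100000 nM in this assay, at which 4 of the 4 values shown sit. The compounds shown leave open how they rank against one another in this assay, and which change to the shared core would give a measured number.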